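The source may hold more compounds than are shown below. What is called first, only, known or untested is meant among the compounds shown, and "the series" means these compounds.

In a functional assay on MIA PaCa-2 cells (Homo sapiens) for inhibition, read by MTT assay, with a stated time of 3 days (on this read-out higher numbers stand for weaker inhibition and lower numbers for stronger inhibition), compound 1 `CCN(CC)S(=O)(=O)c1ccc(S(=O)(=O)N2CCC[C@@H](C(=O)N[C@H]3CCOC3)C2)cc1` gives 290 nM, and compound 2 `CCN(CC)S(=O)(=O)c1ccc(S(=O)(=O)N2CCC[C@@H](C(=O)N3CCC(COC)CC3)C2)cc1` gives 50 nM, the lower of the two numbers. Compound 3 `CCN(CC)S(=O)(=O)c1ccc(S(=O)(=O)N2CCC[C@@H](C(=O)N3CCS(=O)(=O)CC3)C2)cc1` carries 1,1-dioxothiomorpholin-4-yl in place of 4-(methoxymethyl)piperidin-1-yl on a carbonyl carbon. Going by the values given here, only one measured step changes the group at this place, a 5.8-fold lower number from compound 1 to compound 2 (0.76 log units; beyond the scatter), which is modest but beyond the scatter. With that single step as a guide, a change of similar size toward a higher number is expected, an estimated 3.6-fold higher number from compound 2 to compound 3 (0.56 log units; beyond the scatter). For compound 3 the expected value is 180 nM, with an estimated range of 50 nM to 600 nM.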

Compound 3, half-maximal inhibitory concentration: 220 nM
The estimate for compound 3 lay 1.2-fold (0.09 log units) below the measured number, within the range that was stated.
By their numbers in this assay, from the lowest: compound 2; then compounds 3 and 1 (each within the scatter of the next).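

In this assay the step of a 4.4-fold higher number from compound 2 to compound 3 (0.64 log units; beyond the scatter) shows that a six-membered non-aromatic ring on this carbonyl carbon does not by itself keep the number as low as in compound 2. The step of a 1.3-fold lower number from compound 1 to compound 3 (0.12 log units; within the scatter) leaves 1,1-dioxothiomorpholin-4-yl level with (oxolan-3-yl)amino at this place. No measurement at hand accounts for these differences. Going by these compounds, it remains open whether the low number of compound 2 depends on the methoxymethyl chain or on the ring that carries it. Plain piperidin-1-yl and morpholin-4-yl groups at this carbonyl carbon would help separate the two.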